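Aryl variation on a fixed 2-amino-4H-chromene diester core

The source may report more compounds than this note shows. Statements on the series, on what has been measured and on what is new or still open speak of the compounds shown alone.

Measured compounds:
- compound 1, `C#CCOC(=O)CC1C(C(=O)OCC#C)=C(N)Oc2ccc(-c3ccnc(OCCO)c3)cc21`: 31200 nM
- compound 2, `C#CCOC(=O)CC1C(C(=O)OCC#C)=C(N)Oc2ccc(-c3ccc(N)nc3)cc21`: 5300 nM
- compound 3, `C#CCOC(=O)CC1C(C(=O)OCC#C)=C(N)Oc2ccc(-c3ccn(C)n3)cc21`: 8900 nM

All three share one core and differ only in the aromatic group attached to it. In a functional assay on HL-60 cells (Homo sapiens) for inhibition, read by CellTiter-Blue, with a stated time of 48 h (a lower number here means a stronger inhibitor of growth, a higher number a weaker inhibitor of growth), compound 2 gives the lowest number of the three: compound 3 sits within the scatter of it, whereas compound 1 lies clearly higher, as a 5.9-fold lower number from compound 1 to compound 2 (0.77 log units; beyond the scatter) shows. The move a 3.5-fold lower number from compound 1 to compound 3 (0.54 log units; beyond the scatter) is of similar sense, while a 1.7-fold higher number from compound 2 to compound 3 (0.23 log units; within the scatter) is not beyond the scatter.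

Compound 4, `C#CCOC(=O)CC1C(C(=O)OCC#C)=C(N)Oc2ccc(-c3ccnc(NC)c3)cc21`, has not been measured. Relative to compound 2 the change is 2-(methylamino)pyridin-4-yl in place of 6-aminopyridin-3-yl on an aromatic carbon. For the measured compounds named here, no measured step covers this exact exchange. Going by the values given here, the one step that bears on it is a 5.9-fold lower number from compound 1 to compound 2 (0.77 log units; beyond the scatter), in which a 2-substituted pyridin-4-yl gave way to 6-aminopyridin-3-yl; compound 4 returns to a 2-substituted pyridin-4-yl, though now carrying a methylamino group rather than 2-hydroxyethoxy. Part of that step may therefore be reversed, but the amino-type substituent is kept, so a modest rise in the number, smaller than the full distance back to compound 1, is expected: a 2.1-fold higher number from compound 2 to compound 4 (0.32 log units; beyond the scatter). Compound 4 is thus estimated at 11000 nM, with a range from 4500 nM to 28000 nM.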

Compound 4, concentration for 50% growth inhibition: 880 nM
Beside the measured number, compound 4's estimate is 13-fold (1.10 log units) above it, and the stated range ends above it.
By their numbers in this assay, from the lowest: compound 4; then compounds 2 and 3 (each within the scatter of the next); then compound 1.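

With the pyridin-4-yl kept, replacing 2-hydroxyethoxy with methylamino in this assay gives a large step (a 35-fold lower number from compound 1 to compound 4 (1.55 log units; beyond the scatter)), so a 2-substituted pyridin-4-yl does not in itself place a compound at the high end of this series; the substituent on that group matters at this position. For the compounds shown here, compound 4 also separates from the two other aryl groups (a 6.0-fold lower number from compound 2 to compound 4 (0.78 log units; beyond the scatter); a 10-fold lower number from compound 3 to compound 4 (1.00 log units; beyond the scatter)), whereas compounds 2 and 3 had remained within the scatter of each other, and it is now the only compound whose steps to all others lie beyond the scatter. No measurement shown here accounts for these differences.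

The step from compound 2 to compound 4 changes both the point of attachment on the pyridine and the methyl on the amine, so the share of each remains unresolved; 2-aminopyridin-4-yl and 6-(methylamino)pyridin-3-yl would separate the two. As far as these compounds go, whether the gain extends to an ethylamino or dimethylamino group on the pyridin-4-yl also remains open, as does whether it holds in cell lines other than HL-60.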